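The source may report more compounds than this note shows. Statements on the series, on what has been measured and on what is new or still open speak of the compounds shown alone.

Measured so far in a functional assay on HL-60 cells (Homo sapiens) for antiproliferative activity, read by sulforhodamine B assay, with a stated time of 72 h; on this read-out lower numbers stand for stronger inhibition and higher numbers for weaker inhibition:

Compound 1 `Cc1cccc(NC(=S)N/N=C/c2ccc3ccccc3n2)c1` gives > 100000 nM, a limit of the assay.
Compound 2 `S=C(NCc1ccccc1)N/N=C/c1ccc2ccccc2n1` gives 21900 nM.
Compound 3 `NC(=S)N/N=C/c1cc2ccccc2s1` gives > 100000 nM, a limit of the assay.

Going by the values given here, compound 2 is the only compound of the three with a number in this assay; the other two values are limits. Among the compounds with values here, the one measured step that bears on the change to be made here is the one from compound 1 to compound 2: an at least 4.5-fold lower number from compound 1 to compound 2 (0.65 log units; beyond the scatter). That step moved from an aryl group to a benzyl group on the amide-type nitrogen, and the direction was towards a lower number.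

Compound 4 `Cc1ccccc1NC(=S)N/N=C/c1ccc2ccccc2n1` differs from compound 2 by 2-methylphenyl in place of benzyl on an amide-type nitrogen. This is close to the reverse of the step from compound 1 to compound 2, now with the methyl at a different place on the phenyl ring, so the expectation for compound 4 runs in the opposite direction, towards a higher number in this assay. Because the limit of > 100000 nM in this assay, at which 2 of the 3 values shown sit, holds two of the three values shown, there is a fair chance that compound 4 also returns only a limit. The estimate for compound 4 is 55000 nM, with a range from 12000 nM to 200000 nM. The expected step from compound 2 to compound 4 is a 2.5-fold higher number from compound 2 to compound 4 (0.40 log units; beyond the scatter).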

Compound 4, half-maximal inhibitory concentration: 73200 nM
Beside the measured number, compound 4's estimate is 1.3-fold (0.12 log units) below it, within the range that was stated.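

In this assay, benzyl and 2-methylphenyl bring the same atoms, joined differently, to the amide-type nitrogen on the thiocarbonyl carbon, and this exchange gives a 3.3-fold higher number from compound 2 to compound 4 (0.52 log units; beyond the scatter), so this position responds to how those carbons are arranged and not only to how many there are. Compound 1 gives > 100000 nM, which is a limit of the assay. Against that limit only a floor can be read, an at least 1.3-fold lower number from compound 1 to compound 4 (0.13 log units; that floor lies within the scatter), so no order between 2-methylphenyl and 3-methylphenyl can be stated, while benzyl in compound 2 keeps the lowest number of the three groups on this nitrogen.

Still open, going by these compounds, is whether the lower number of compound 2 goes with the single carbon link to the phenyl ring or with the absence of a methyl on that ring, a question that unsubstituted phenyl, a longer phenylethyl chain, or a benzyl carrying an amine or a carboxylic acid would address. Any such comparison may run into the same limit that already holds two of the compounds shown: the limit of > 100000 nM in this assay, at which 2 of the 4 values shown sit.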